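The source may hold more compounds than are shown below. What is called first, only, known or untested is meant among the compounds shown, and "the series" means these compounds.

Compound 1 `Cc1cc(-n2nccn2)cc(C(=O)NNS(=O)(=O)c2ccccc2)c1F`: in an ADME assay on Caco-2 cells (Homo sapiens) for permeability, read by LC-MS, in the apical to basolateral direction, with a stated time of 90 min (on this read-out higher numbers stand for higher permeability and lower numbers for lower permeability), compound 1 gives 53 10^-6 cm/s.
Compound 2 `Cc1cc(-c2ncccn2)cc(C(=O)NNS(=O)(=O)c2ccccc2)c1F`: in this assay compound 2 gives 77 10^-6 cm/s.
Compound 3 `CCOc1cc(C)cc(C(=O)NNS(=O)(=O)c2ccccc2F)c1`: in this assay compound 3 gives 47 10^-6 cm/s.

Compound 2 gives the highest of these three numbers, yet compound 1 and compound 3 both lie within the scatter of it, so the three cannot really be told apart. Compound 4 `Cc1cc(-n2cccn2)cc(C(=O)NNS(=O)(=O)c2ccccc2)c1F` has not yet been measured. It differs from compound 2 in one place: 1H-pyrazol-1-yl in place of pyrimidin-2-yl on an aromatic carbon. Among the compounds with values here, only one measured step bears on this, the exchange of one small aromatic ring for another on an aromatic carbon. Because a 1.5-fold higher number from compound 1 to compound 2 (0.16 log units; within the scatter) stayed within the scatter, no step beyond the scatter is expected in this assay; the estimated step is a 1.2-fold lower number from compound 2 to compound 4 (0.07 log units; within the scatter). Compound 4 is therefore expected to give about 65 10^-6 cm/s, between 35 10^-6 cm/s and 120 10^-6 cm/s.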

Compound 4, apparent permeability in the Caco-2 assay: 48 10^-6 cm/s
Beside the measured number, compound 4's estimate is 1.4-fold (0.13 log units) above it, within the range that was stated.
By their numbers in the Caco-2 assay, from the lowest: compounds 3, 4, 1 and 2 (each within the scatter of the next).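

In the Caco-2 assay, this position accepts all three small aromatic rings without a readable change, with a 1.6-fold lower number from compound 2 to compound 4 (0.21 log units; within the scatter) and a 1.1-fold lower number from compound 1 to compound 4 (0.04 log units; within the scatter). The same exchange does matter in a physicochemical assay for solubility, read by nephelometry, in phosphate buffer, measured as kinetic solubility, at pH 6.5 (a lower number here means a less soluble compound, a higher number a more soluble compound), where compound 2 gives 50 ug/mL and compound 4 gives 6.3 ug/mL. So 1H-pyrazol-1-yl in place of pyrimidin-2-yl at this position costs solubility, although no readable step appears in permeability: the measured solubility of compound 2, 50 ug/mL, and of compound 4, 6.3 ug/mL, a 7.9-fold lower number (0.90 log units; beyond the scatter)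

Two compounds cannot separate the change in ring size from the change in where the nitrogens sit. Going by these compounds, how an amine or a carboxylic acid on this aromatic carbon would move either number also remains open.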